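The source may hold more compounds than are shown below. What is called first, only, known or untested is meant among the compounds shown, and "the series" means these compounds.

Measured so far in a functional assay for inhibition, with Homo sapiens as the target; on this read-out higher numbers stand for weaker binding and lower numbers for tighter binding
Compound 1 `CC(C)(Oc1ccccc1O)C1OCC(C/C=C\CCC(=O)O)C(c2cccnc2)O1` gives 95.5 nM
Compound 2 `Cc1ccc(SC(C)(C)C2OCC(C/C=C\CCC(=O)O)C(c3cccnc3)O2)c([N+](=O)[O-])c1` gives 158 nM

Compound 2 stands at 158 nM in this assay and cannot be told apart from compound 1 there, as a 1.7-fold higher number from compound 1 to compound 2 (0.22 log units; within the scatter) shows. Compound 3 `CC(C)(Cc1ccccc1)C1OCC(C/C=C\CCC(=O)O)C(c2cccnc2)O1` has not yet been measured. Compared with compound 2 it carries one change (a group of 7 heavy atoms (7 carbon; one six-membered aromatic ring of carbon only) in place of a group of 11 heavy atoms (7 carbon, 1 nitrogen, 2 oxygen, 1 sulfur; one six-membered aromatic ring of carbon only), on a saturated chain carbon bound to two saturated chain carbons and a saturated ring carbon) and the benzyl group enters on the same saturated chain carbon. Going by the values given here, the one measured step at that place is a 1.7-fold higher number from compound 1 to compound 2 (0.22 log units; within the scatter) and so compound 2 gives no reason to expect a shift beyond the scatter. The estimated step is a 1.3-fold lower number from compound 2 to compound 3 (0.10 log units; within the scatter) and no more. Compound 3 is expected near 125 nM with an estimated span from 45 nM to 340 nM as its range.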

Compound 3, dissociation constant: 513 nM
Compound 3: middle estimate off by 4.1-fold (0.61 log units), on the low side; measured number above the stated range.
By their numbers in this assay, from the lowest: compounds 1 and 2 (each within the scatter of the next); then compound 3.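

In this assay the saturated chain carbon bound to two saturated chain carbons and a saturated ring carbon proves sensitive to the group it carries: benzyl gives a 3.2-fold higher number from compound 2 to compound 3 (0.51 log units; beyond the scatter) and also a 5.4-fold higher number from compound 1 to compound 3 (0.73 log units; beyond the scatter), both beyond the scatter, whereas the earlier step at this place stayed within it. Compounds 1 and 2 carry an oxygen or a sulfur where compound 3 has a carbon on its ring, and they also carry ring groups that compound 3 lacks. No measurement here explains the shift.

Which of these differences matters remains open. Plain phenoxy or phenylthio at this place would separate the linking atom from the hydroxy, nitro and methyl groups.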